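The source may hold more compounds than are shown below. What is called first, only, known or untested is meant among the compounds shown, and "the series" means these compounds.

Measured so far in a functional assay on HT-29 cells (Homo sapiens) for inhibition, read by sulforhodamine B assay, with a stated time of 72 h; on this read-out higher numbers stand for weaker inhibition and lower numbers for stronger inhibition:
- compound 1 `COc1cc2c(Nc3cccc(Br)c3)ncnc2cc1OCCCn1ccnc1[N+](=O)[O-]`: 10900 nM
- compound 2 `COc1cc2c(Nc3cccc(Br)c3)ncnc2cc1OCCCCn1ccnc1[N+](=O)[O-]`: 4020 nM
- compound 3 `COc1cc2c(Nc3cccc(Br)c3)ncnc2cc1OCCCCCn1ccnc1[N+](=O)[O-]`: 5050 nM

Compound 3 lies within the scatter of compound 2, with a 1.3-fold higher number from compound 2 to compound 3 (0.10 log units; within the scatter). Compound 1 carries the highest number of the three, and the comparison gives a 2.2-fold lower number from compound 1 to compound 3 (0.33 log units; beyond the scatter).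

Compound 4 `COc1cc2c(Nc3cccc(Br)c3)ncnc2cc1OCCOCCn1ccnc1[N+](=O)[O-]` is next, with 2-(2-nitro-1H-imidazol-1-yl)ethoxy in place of 3-(2-nitro-1H-imidazol-1-yl)propyl on a saturated chain carbon, two bonds along the chain from an oxygen on an aromatic ring.

Among the measured compounds shown here, no measured compound carries 2-(2-nitro-1H-imidazol-1-yl)ethoxy, so the closest guidance comes from the changes within the chain. These steps are modest or smaller: a 2.7-fold lower number from compound 1 to compound 2 (0.43 log units; beyond the scatter), and a 2.2-fold lower number from compound 1 to compound 3 (0.33 log units; beyond the scatter), and a 1.3-fold higher number from compound 2 to compound 3 (0.10 log units; within the scatter). On that basis, no step beyond the scatter is expected in this assay.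

The expected step is a 1.2-fold higher number from compound 3 to compound 4 (0.07 log units; within the scatter).

For compound 4 the estimated value is 6000 nM, with an expected range from 2500 nM to 14000 nM.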

Compound 4, half-maximal inhibitory concentration: 10800 nM
For compound 4 the middle estimate is 1.8-fold (0.26 log units) below the measured one, within the range that was stated.
By their numbers in this assay, from the lowest: compounds 2 and 3 (each within the scatter of the next); then compounds 4 and 1 (each within the scatter of the next).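

In this assay, among the compounds shown here, 2-(2-nitro-1H-imidazol-1-yl)ethoxy in place of 3-(2-nitro-1H-imidazol-1-yl)propyl, an oxygen in the chain where the earlier compounds have a carbon, gives a 2.1-fold higher number from compound 3 to compound 4 (0.33 log units; beyond the scatter), and the comparison with the next shorter all-carbon chain gives a 2.7-fold higher number from compound 2 to compound 4 (0.43 log units; beyond the scatter). The earlier compounds shown here varied only chain length, whereas these steps show that chain composition at this position can also shift the number beyond the scatter, with the comparison against the shortest chain reading a 1.0-fold lower number from compound 1 to compound 4 (0.00 log units; within the scatter). Nothing available explains this result.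

From the compounds shown here alone, whether the step follows the oxygen itself remains open, and an amine at that place in the chain or a longer chain carrying the same oxygen would test this. Also open, going by these compounds, is how a chain ending in an amine or a carboxylic acid, rather than 2-nitro-1H-imidazol-1-yl, would read here.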